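Methyl in Place of Phenyl on a Double-Bonded Nitrogen

The compounds below may be only part of what the source reports. "The series", "measured", "known", "first", "only" and "open" are said of these compounds alone.

Compound 1 `O=C1/C(=C/c2ccn(Cc3ccccc3)c2)S/C(=N\c2ccccc2)N1C1CCCCC1` gives > 200000 nM in an ADME assay on L6 cells (Rattus norvegicus) for cytotoxicity, read by microscopy and resazurin assay, with a stated time of 72 h (a lower number here means that less compound is needed, a higher number that more compound is needed for the effect), a limit. Compound 2 `Cc1cc(/C=C2\S/C(=N\c3ccccc3)N(C3CCCCC3)C2=O)c(C)[nH]1` gives 23000 nM. Compound 3 `CN1C(=O)/C(=C/c2ccn(Cc3ccccc3)c2)S/C1=N\c1ccccc1` gives > 240000 nM, again a limit.

Compound 3 therefore stands at a limit in this assay, not at a number, and compound 1 sits at a limit too, as the limit of > 200000 nM in this assay, at which 1 of the 3 values shown sits, and the limit of > 240000 nM in this assay, at which 1 of the 3 values shown sits, show. For the measured compounds named here, the only step measured between these compounds, a step that the two limits leave unreadable from compound 1 to compound 3, is unreadable for that reason.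

Compound 4 `C/N=C1\S/C(=C\c2ccn(Cc3ccccc3)c2)C(=O)N1C` differs from compound 3 by methyl in place of phenyl on a double-bonded nitrogen. Going by the values given here, no measured step touches this change, so no size is expected beyond the scatter, and compound 4 is expected to sit at a limit again; the estimate is 240000 nM, between 60000 nM and 600000 nM, a step of a number no higher from compound 3 to compound 4 (the limit leaves the size open).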

Compound 4, half-maximal effective concentration: > 290000 nM
Compound 4 was reported as a limit (the forecaster's own chance of this, stated with the estimate: 70%); middle value at least 1.2-fold (0.08 log units) from the limit.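

Compound 3 and compound 4 both stand at limits, so the step between them cannot be read. The compounds shown leave open how far methyl in place of phenyl on a double-bonded nitrogen shifts the value in this assay.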